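This account rests on a few compounds, and the source may have more. Where it says the series, first, only, none or still open, it means among the compounds named here.

For the measured compounds named here, in a functional assay, with a stated time of 6 min (on this read-out lower numbers stand for stronger inhibition and higher numbers for weaker inhibition), two compounds with a shared core have numbers so far. Compound 1 `S=c1oc(-c2ccc3c(c2)OCCO3)nn1CNc1ccccc1Cl` gives 7230 nM and compound 2 `S=c1oc(-c2ccc3c(c2)OCCO3)nn1CNc1ccc(Cl)cc1` gives 7270 nM, which places compound 2 level with compound 1 within the scatter. The compound still to be measured, compound 3 `S=c1oc(-c2ccc3c(c2)OCCO3)nn1CNc1cc(Cl)ccc1Cl`, differs from compound 2 by 2,5-dichlorophenyl in place of 4-chlorophenyl on an amine nitrogen, with 2,5-dichlorophenyl in place of 4-chlorophenyl on an amine nitrogen. Going by the values given here, only one measured step bears on this change: a 1.0-fold higher number from compound 1 to compound 2 (0.00 log units; within the scatter), which exchanges 2-chlorophenyl for 4-chlorophenyl and stays within the scatter. Among the compounds with values here, no measured compound yet carries the 2,5-dichlorophenyl group, so the evidence is thin. In this assay no step beyond the scatter is therefore expected, and the estimated step is a 1.2-fold lower number from compound 2 to compound 3 (0.08 log units; within the scatter). For compound 3 the expected value is 6000 nM, with an estimated range from 2500 nM to 14000 nM.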

Compound 3, half-maximal inhibitory concentration: 5420 nM
Compound 3: the middle estimate sits 1.1-fold (0.04 log units) above what was measured; measured number inside the range.
By their numbers in this assay, from the lowest: compounds 3, 1 and 2 (each within the scatter of the next).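

In this assay, the earlier compounds had shown only a single chlorine changing place on the phenyl group; compound 3 shows that a phenyl group with two chlorines on the amine nitrogen also stays within the scatter of both single-chlorine compounds. Putting 2,5-dichlorophenyl in place of 4-chlorophenyl gives a 1.3-fold lower number from compound 2 to compound 3 (0.13 log units; within the scatter) and putting chloro in place of hydrogen on an aromatic carbon gives a 1.3-fold lower number from compound 1 to compound 3 (0.13 log units; within the scatter), so neither change moves the number beyond the scatter. No measurement offered here accounts for this flat result.

From the compounds shown here alone, all three compounds carry chlorophenyl groups at this place, so it remains open whether an unsubstituted phenyl, a methoxyphenyl, a pyridine ring or a cyclohexyl group would shift the number beyond the scatter. Going by these compounds, it also remains open whether a change elsewhere on the shared core would do so.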